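Chloro added to compound 3: expected effect on growth inhibition

This account rests on a few compounds, and the source may have more. Where it says the series, first, only, none or still open, it means among the compounds named here.

Measured compounds:
compound 1 `Oc1ccc(O)c(-c2cc(-c3ccc(Cl)cc3)nn2-c2ccccc2)c1`, 32500 nM
compound 2 `NS(=O)(=O)c1ccc(-n2nc(-c3ccc(Cl)cc3)cc2-c2cc(O)ccc2O)cc1`, 38900 nM
compound 3 `CC(=O)NS(=O)(=O)c1ccc(-n2nc(-c3ccccc3)cc2-c2cc(O)ccc2O)cc1`, 100000 nM

Among the compounds with values here, in a functional assay on cells (Melanoma cell, Homo sapiens) for cytotoxicity, read by sulforhodamine B assay, with a stated time of 48 h (on this read-out higher numbers stand for weaker inhibition of growth and lower numbers for stronger inhibition of growth), compound 1 gives 32500 nM and compound 2 gives 38900 nM; the only single-point step among the measured compounds, a 1.2-fold higher number from compound 1 to compound 2 (0.08 log units; within the scatter), is within the scatter. Compound 3, which carries an acetylated sulfonamide and no chloro, gives the highest number of the three, 100000 nM; it stands beyond the scatter from compound 2 and further still from compound 1.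

Compound 4 `CC(=O)NS(=O)(=O)c1ccc(-n2nc(-c3ccc(Cl)cc3)cc2-c2cc(O)ccc2O)cc1` differs from compound 3 by chloro in place of hydrogen on an aromatic carbon. Within the data shown here, no measured step covers this change on its own: compound 2 and compound 3 differ in two places at once, the chloro and the acetyl on the sulfonamide, so their values cannot be split between the two. Going by these compounds, what can be said is that both chloro-bearing compounds, compound 1 and compound 2, sit at lower numbers than compound 3, while the role of the acetyl remains untested.

Compound 4 is therefore expected to give a somewhat lower number than compound 3, with the step of a 1.8-fold lower number from compound 3 to compound 4 (0.26 log units; within the scatter) as the estimate. The estimated value for compound 4 in this assay is 55000 nM, within a range of 25000 nM to 100000 nM.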

Compound 4, concentration for total growth inhibition: 60100 nM
Compound 4: middle estimate off by 1.1-fold (0.04 log units), on the low side, and the stated range covers the measured number.
By their numbers in this assay, from the lowest: compounds 1, 2, 4 and 3 (each within the scatter of the next, the first and the last beyond it).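

In this assay, the change from phenyl to 4-chlorophenyl, with the chloro para to a large group, can now be read on its own: a 1.7-fold lower number from compound 3 to compound 4 (0.22 log units; within the scatter), so the chloro at this position shifts the number by no more than the usual scatter. The acetyl on the sulfonamide nitrogen can also be read alone, as a 1.5-fold higher number from compound 2 to compound 4 (0.19 log units; within the scatter), and adding the whole acetylsulfamoyl gives a 1.8-fold higher number from compound 1 to compound 4 (0.27 log units; within the scatter), so neither change moves the number beyond the scatter. No measurement shown here offers any explanation for these small steps.

Going by these compounds, whether bromo or methoxy in place of the chloro, or a carboxylic acid or an amine in place of the acetylsulfamoyl group, would give a step beyond the scatter remains open. The hydroxy groups of the shared core are the same in all four compounds, so what they contribute to growth inhibition in this assay is also left open.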